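The source may hold more compounds than are shown below. What is called first, only, known or untested is meant among the compounds shown, and "the series" means these compounds.

Measured compounds: compound 1 `CCOC(=O)CCCCCOC(COCc1ccc(OC)cc1)Cn1ccnc1` gives 120 nM in a functional assay on a cell-free system (plasma) for inhibition of Thromboxane-A synthase (Homo sapiens); a higher number here means a weaker inhibitor, a lower number a stronger inhibitor; compound 2 `CCOC(=O)CCCCCCOC(COCc1ccc(OC)cc1)Cn1ccnc1` gives 4000 nM in this assay.

Compound 2 holds the highest number of the two, with compound 1 a step away by a 33-fold higher number from compound 1 to compound 2 (1.52 log units; beyond the scatter). Compound 3 `COc1ccc(COCC(Cn2ccnc2)OCCCCCCC(C)(C)C(=O)O)cc1` differs from compound 2 by 1-carboxy-1-methylethyl in place of ethoxycarbonyl on a saturated chain carbon, six bonds along the chain from an oxygen on a saturated carbon. Among the measured compounds shown here, the one measured step, a 33-fold higher number from compound 1 to compound 2 (1.52 log units; beyond the scatter), concerns chain length alone and does not touch an ester-to-acid exchange, so no measured step bears directly on this change. Compound 3 is therefore expected near a step of a 2.7-fold lower number from compound 2 to compound 3 (0.43 log units; beyond the scatter), with its value in this assay estimated at 1500 nM, within 250 nM to 9000 nM.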

Compound 3, half-maximal inhibitory concentration: > 20000 nM
Compound 3 gave a limit, no number; the forecaster's own chance of this, stated with the estimate: 5%; middle value at least 13-fold (1.12 log units) away from the limit.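

In this assay compound 3 gives a limit and not a number: the limit of > 20000 nM in this assay, at which 1 of the 3 values shown sits. The exchange of ethoxycarbonyl for 1-carboxy-1-methylethyl at this chain end is a further weakening on top of the chain lengthening, with an at least 5.0-fold higher number from compound 2 to compound 3 (0.69 log units; beyond the scatter) as its size. Measured against the shorter ester, the combined change comes to an at least 160-fold higher number from compound 1 to compound 3 (2.22 log units; beyond the scatter) and is large.

The change brings in the carboxyl and the two methyl groups together, so their shares stay apart and unknown. Going by these compounds, whether an amide at this chain end would fare better remains open.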